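The source may hold more compounds than are shown below. What is called first, only, known or untested is meant among the compounds shown, and "the series" means these compounds.

In an ADME assay on microsomes from liver (Mus musculus) for metabolic stability, read by LC-MS, using NADPH, with a stated time of 60 min, tested at 0.1 uM (a higher number here means that more of the compound is left, a lower number that less of the compound is left), compound 1 (`Fc1ccc(Nc2cc3[nH]c(Nc4cc(N5CCNCC5)ccn4)nc3cn2)cc1C(F)(F)F`) gives 78% and compound 2 (`Fc1ccc(Nc2cc3[nH]c(Nc4ccc(N5CCNCC5)cn4)nc3cn2)cc1F`) gives 75%. Within the data shown here, these two values lie within the scatter of each other, so compound 1 stands level with the only other measured compound. Compound 3 (`C[C@@H]1CN(C(=O)c2ccnc(Nc3nc4cnc(Nc5ccc(F)c(C(F)(F)F)c5)cc4[nH]3)c2)C[C@H](C)N1`) carries (3,5-dimethylpiperazin-1-yl)carbonyl in place of piperazin-1-yl on an aromatic carbon of a six-membered aromatic ring with 1 nitrogen, meta to a large group and opposite the ring nitrogen ((3,5-dimethylpiperazin-1-yl)carbonyl in place of piperazin-1-yl on an aromatic carbon). Among the measured compounds shown here, no measured pair differs in one place, so the data do not yet size this change. In this assay a small fall is expected, a number 8 percentage points lower from compound 1 to compound 3 (within the scatter), and it may not clear the scatter. For compound 3 the estimated value is 70%, with an expected range of 50% to 88%.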

Compound 3, percent of the compound remaining: 90%
Compound 3: middle estimate off by 20 percentage points, on the low side; the measured number lies above the stated range.
By their numbers in this assay, from the lowest: compounds 2 and 1 (each within the scatter of the next); then compound 3.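

In this assay, (3,5-dimethylpiperazin-1-yl)carbonyl in place of piperazin-1-yl gives a number 12 percentage points higher from compound 1 to compound 3 (beyond the scatter), so this place on the ring opposite the ring nitrogen takes the larger group with more of the compound left, not less. Among these compounds, this is the first step that can be sized, and as a single pair it gives a direction for this one change only. Among the compounds shown here, nothing measured so far accounts for the step.

Going by these compounds, the change brings in a carbonyl, two methyl groups and two defined stereocentres at once, so the share of each stays open; a (piperazin-1-yl)carbonyl group, without the methyl groups, would separate the carbonyl from the rest. On these data alone, whether a morpholin-4-ylcarbonyl group or a simple dimethylamide at this place behaves the same way also remains open.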